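Aryl swap on the ring nitrogen: estimate for compound 4

The source may hold more compounds than are shown below. What is called first, only, known or untested is meant among the compounds shown, and "the series" means these compounds.

Three compounds sharing the core of compound 1 `Nc1scc(CN2CCN(c3ccc(Cl)cc3Cl)CC2)c1C(=O)c1ccc(Cl)cc1` have been run in a functional assay on CHO cells with adenosine receptor A1 (Homo sapiens) as the target, read by cAMP accumulation and immunoassay, with a stated time of 6 min, tested at 10 uM; a higher number here means a weaker effect of the compound at the concentration tested, a lower number a stronger effect. Compound 1 gives -74%. Compound 2 `Nc1scc(CN2CCN(c3cccc(F)c3)CC2)c1C(=O)c1ccc(Cl)cc1` gives -82%, and compound 3 `Nc1scc(CN2CCN(c3cc(F)cc(F)c3)CC2)c1C(=O)c1ccc(Cl)cc1` gives -79%. Compound 1 thus holds the highest of the three numbers, but the nearest of the other two lies a number 5 percentage points lower from compound 1 to compound 3 (within the scatter) and the furthest a number 8 percentage points lower from compound 1 to compound 2 (within the scatter), both within the scatter, so no order among the three is claimed. Between the two fluorinated analogues the step is a number 3 percentage points higher from compound 2 to compound 3 (within the scatter), also within the scatter.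

Compound 4 `Nc1scc(CN2CCN(c3c(F)cc(F)cc3F)CC2)c1C(=O)c1ccc(Cl)cc1` differs from compound 1 by 2,4,6-trifluorophenyl in place of 2,4-dichlorophenyl on an amine nitrogen in a ring. For the measured compounds named here, the steps that bear on this change, a number 8 percentage points lower from compound 1 to compound 2 (within the scatter) and a number 5 percentage points lower from compound 1 to compound 3 (within the scatter), are replacements of the same aryl group on the same ring nitrogen, and neither moved the number beyond the scatter. Nothing in the data separates one substituted phenyl from another at this position. The expected outcome is therefore no step beyond the scatter, a number 2 percentage points lower from compound 1 to compound 4 (within the scatter). Compound 4 is estimated at -76%, in a range from -88% to -62%.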

Compound 4, a percentage reported as activity, at one concentration (the size of the read-out at that concentration, not a potency): -78%
For compound 4 the middle estimate is 2 percentage points above the measured one; the measured number falls inside the stated range.
By their numbers in this assay, from the lowest: compounds 2, 3, 4 and 1 (each within the scatter of the next).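

Against 2,4-dichlorophenyl (a number 4 percentage points lower from compound 1 to compound 4 (within the scatter)), 3,5-difluorophenyl (a number 1 percentage points higher from compound 3 to compound 4 (within the scatter)) and 3-fluorophenyl (a number 4 percentage points higher from compound 2 to compound 4 (within the scatter)), 2,4,6-trifluorophenyl on the amine nitrogen in a ring shows no step beyond the scatter in this assay. The four substituted phenyl groups, chlorinated or fluorinated, therefore form a single set at this position, and no compound shown goes against that. No measurement on hand explains why the number stays within the scatter across these aryl changes.

On these data alone, whether a group other than halogenated phenyl on this nitrogen, such as a benzyl, an acetyl, or a phenyl carrying a carboxylic acid or an amine, would give a step beyond the scatter remains open. As far as these compounds go, the rest of the core of compound 1 is the same in all four compounds, so the effect of changes there also remains open.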